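The source may hold more compounds than are shown below. What is called first, only, known or untested is meant among the compounds shown, and "the series" means these compounds.

In a functional assay on the whole organism with Rattus norvegicus as the target (a lower number here means that less compound is needed, a higher number that more compound is needed for the effect), compound 3 `O=C(O)C(=O)Nc1nc(-c2cc(Cl)no2)cs1` gives > 30 mg/kg, which is a limit of the assay and not a number. Compound 1 `CCOCCOC(=O)C(=O)Nc1nc(-c2cc(Cl)no2)cs1` gives > 30 mg/kg, which is also a limit. Together they make up (the limit of > 30 mg/kg in this assay, at which 2 of the 3 values shown sit), so compound 3 has no readable potency to start from. Compound 4 `COc1cc(-c2csc(NC(=O)C(=O)O)n2)on1` carries methoxy in place of chloro on an aromatic carbon of the ring that also bears the large group, and the change is methoxy in place of chloro on an aromatic carbon.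

The same exchange has been measured once, on the 2-ethoxyethyl series. Where compound 1 bears chloro, compound 2 `CCOCCOC(=O)C(=O)Nc1nc(-c2cc(OC)no2)cs1` bears methoxy and gives 11 mg/kg. Going by the values given here, that exchange produced an at least 2.7-fold lower number from compound 1 to compound 2 (0.43 log units; beyond the scatter), the only readable step here. The other measured step, hydrogen in place of 2-ethoxyethyl, is a step that the two limits leave unreadable from compound 1 to compound 3, so the data do not show how far the exchange carries over to compounds with hydrogen on that oxygen.

Going by compound 2 at 11 mg/kg, a move of modest size towards a lower number is expected in this assay, though this rests on a single pair. The expected change is an at least 2.0-fold lower number from compound 3 to compound 4 (0.30 log units; that floor lies within the scatter). For compound 4 the estimated value is 15 mg/kg, with an expected range from 5 mg/kg to 40 mg/kg.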

Compound 4, dose for half-maximal effect: 8 mg/kg
Compound 4: middle estimate off by 1.9-fold (0.27 log units), on the high side, and the stated range covers the measured number.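

In this assay, going by these compounds alone, the exchange of chloro for methoxy, until now seen only with the 2-ethoxyethyl group, also holds with hydrogen on that oxygen, giving an at least 3.7-fold lower number from compound 3 to compound 4 (0.57 log units; beyond the scatter). Methoxy on this aromatic carbon, next to the ring nitrogen, therefore moves the number the same way in both pairs: the same change on two cores in this assay, an at least 2.7-fold lower number (0.43 log units; beyond the scatter) from compound 1 to compound 2 and an at least 3.7-fold lower number (0.57 log units; beyond the scatter) from compound 3 to compound 4; the limit leaves it open whether they differ The exchange of 2-ethoxyethyl for hydrogen, which cannot be read between the two chloro compounds, can be read between the two methoxy compounds, as a 1.4-fold lower number from compound 2 to compound 4 (0.14 log units; within the scatter), so with methoxy in place the two compounds do not differ beyond the scatter.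

On these data alone, the true size of the exchange stays open, as only a floor can be read while both chloro compounds sit at a limit: the limit of > 30 mg/kg in this assay, at which 2 of the 4 values shown sit. Also open is whether ethoxy, an amine or a longer chain on this ring carbon would match methoxy, and whether the parity between the 2-ethoxyethyl and hydrogen compounds extends to another chain on that oxygen, such as ethyl.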